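Compound 3: fluoro for ethoxy on the arylamino ring

The source may hold more compounds than are shown below. What is called first, only, known or untested is meant among the compounds shown, and "the series" means these compounds.

Compound 2 `CCOc1ccc(NC2=C(C(=O)c3ccccc3)C(c3ccc(Br)cc3)N(CCCn3ccnc3)C2=O)cc1` gives 26200 nM in a functional assay on U2OS cells (Homo sapiens) for antiproliferative activity, read by MTT assay, with a stated time of 72 h; on this read-out higher numbers stand for weaker inhibition and lower numbers for stronger inhibition. Among the measured compounds shown here, the only other measured compound, compound 1 `CC(C)OC1=C(C(=O)c2ccccc2)C(c2ccc(Br)cc2)N(CCCn2ccnc2)C1=O`, gives 24800 nM in this assay, and the step of a 1.1-fold higher number from compound 1 to compound 2 (0.02 log units; within the scatter) lies within the scatter, so the two numbers cannot be told apart and compound 2 stands level with compound 1 rather than apart from it.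

Compound 3 `O=C(C1=C(Nc2ccc(F)cc2)C(=O)N(CCCn2ccnc2)C1c1ccc(Br)cc1)c1ccccc1` differs from compound 2 by fluoro in place of ethoxy on an aromatic carbon. For the measured compounds named here, only one measured step exists, a 1.1-fold higher number from compound 1 to compound 2 (0.02 log units; within the scatter), and it concerns the group on the double-bonded ring carbon as a whole, not a substituent on the arylamino ring; it shows that a large exchange at that carbon left the number unchanged. Going by the values given here, no measured step touches the para substituent of the arylamino ring itself, so the present change has no direct precedent and the expectation rests on the flatness seen so far.

The step from compound 2 to compound 3 is therefore expected to stay within the scatter, a 1.0-fold lower number from compound 2 to compound 3 (0.02 log units; within the scatter). Compound 3 is estimated at 25000 nM in this assay, with a range from 10000 nM to 60000 nM.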

Compound 3, half-maximal inhibitory concentration: 30000 nM
Compound 3: the middle estimate sits 1.2-fold (0.08 log units) below what was measured, within the range that was stated.
By their numbers in this assay, from the lowest: compounds 1, 2 and 3 (each within the scatter of the next).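

In this assay, among the compounds shown here, a 1.1-fold higher number from compound 2 to compound 3 (0.06 log units; within the scatter) gives the first reading on the arylamino ring itself: with fluoro in place of ethoxy on an aromatic carbon para to a large group, the two numbers cannot be told apart. The wider exchange gives the same picture, with a 1.2-fold higher number from compound 1 to compound 3 (0.08 log units; within the scatter), so compound 1, compound 2 and compound 3 stand level and no substituent shown on this part of the series separates itself from the others. Nothing measured here offers an explanation for this flatness.

As far as these compounds go, whether any group at the position held by ethoxy and fluoro can move the number beyond the scatter stays open, for instance an amine, a carboxylic acid or a longer alkoxy chain. The parts shared by all three compounds, including the bromo substituent and the benzoyl group on the core, also stay open, since none of the steps shown touches them.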